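Loss of the chloro group: compound 2 to compound 3

A few compounds are considered here, and "the series" means these few. Any claim that something is new, unique, unknown or untested is made for them only; others in the source may bear on it.

Measured compounds:
compound 1 `CC(C)c1onc(-c2ccccc2C(F)(F)F)c1COc1ccc(CCCC(=O)O)cc1`: 4400 nM
compound 2 `CC(C)c1onc(-c2ccccc2Cl)c1COc1ccc(CCCC(=O)O)cc1`: 3800 nM

For the measured compounds named here, in an assay on HEK-293T cells for activation of Bile acid receptor (Homo sapiens), read by a luciferase reporter, with a stated time of 14 h (a lower number here means that less compound is needed, a higher number that more compound is needed for the effect), compound 2 gives 3800 nM, the lowest of the two numbers, and compound 1 gives 4400 nM; the single measured step, a 1.2-fold lower number from compound 1 to compound 2 (0.06 log units; within the scatter), lies within the scatter. Compound 3 `CC(C)c1onc(-c2ccccc2)c1COc1ccc(CCCC(=O)O)cc1` differs from compound 2 by hydrogen in place of chloro on an aromatic carbon. Going by the values given here, no measured step removes a group outright; the only step, exchanging one group for another, stayed within the scatter, so at most a small shift towards a higher number is expected. Compound 3 is therefore estimated at 5500 nM, with a range from 2200 nM to 14000 nM. The expected step is a 1.4-fold higher number from compound 2 to compound 3 (0.16 log units; within the scatter).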

Compound 3, half-maximal effective concentration: 31000 nM
Beside the measured number, compound 3's estimate is 5.6-fold (0.75 log units) below it; measured number above the stated range.
By their numbers in this assay, from the lowest: compounds 2 and 1 (each within the scatter of the next); then compound 3.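

In this assay the change to hydrogen on this aromatic carbon gives an 8.2-fold higher number from compound 2 to compound 3 (0.91 log units; beyond the scatter) and also a 7.0-fold higher number from compound 1 to compound 3 (0.85 log units; beyond the scatter) whereas the exchange of trifluoromethyl for chloro stayed within the scatter. Among these three compounds, what counts at this place is that either group is present rather than which of the two it is. Nothing measured here explains this difference.

On these data alone, whether fluoro, methyl or methoxy on this carbon would behave like chloro and trifluoromethyl or like hydrogen remains open. So does the effect of a second chloro on the same ring.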